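Halophenyl variation on the shared core

This account rests on a few compounds, and the source may have more. Where it says the series, first, only, none or still open, it means among the compounds named here.

Measured so far, in an assay on CHO cells for displacement of a labelled ligand from adenosine receptor A2b (Homo sapiens), read by scintillation counting, with a stated time of 75 min, in the presence of a further agent that is not named here; on this read-out lower numbers stand for stronger inhibition and higher numbers for weaker inhibition:
compound 1 `CCCn1c(=O)[nH]c2nc(-c3ccc(S(=O)(=O)N4CCN(c5cccc(Br)c5)CC4)cc3)[nH]c2c1=O` gives 0.234 nM
compound 2 `CCCn1c(=O)[nH]c2nc(-c3ccc(S(=O)(=O)N4CCN(c5cccc(F)c5)CC4)cc3)[nH]c2c1=O` gives 0.632 nM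
compound 3 `CCCn1c(=O)[nH]c2nc(-c3ccc(S(=O)(=O)N4CCN(c5ccc(Br)cc5)CC4)cc3)[nH]c2c1=O` gives 0.0835 nM

Compound 3 stands lowest of the three: a 2.8-fold lower number from compound 1 to compound 3 (0.45 log units; beyond the scatter) and a 7.6-fold lower number from compound 2 to compound 3 (0.88 log units; beyond the scatter), both beyond the scatter. Compound 4 `CCCn1c(=O)[nH]c2nc(-c3ccc(S(=O)(=O)N4CCN(c5ccc(Cl)cc5F)CC4)cc3)[nH]c2c1=O` differs from compound 3 by 4-chloro-2-fluorophenyl in place of 4-bromophenyl on an amine nitrogen in a ring. The entering group carries chloro rather than bromo and a further fluorine. The step bearing on this is a 2.7-fold higher number from compound 1 to compound 2 (0.43 log units; beyond the scatter), where fluoro in place of bromo raised the number modestly. Among the measured compounds shown here, no measured step covers chloro, or the added fluorine, so the expectation rests on that single step and is uncertain: a modest rise is expected, a 1.9-fold higher number from compound 3 to compound 4 (0.28 log units; within the scatter). Compound 4 is expected at 0.16 nM in this assay, with a range of 0.05 nM to 0.5 nM.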

Compound 4, inhibition constant: 1.91 nM
Compound 4: middle estimate off by 12-fold (1.08 log units), on the low side; measured number above the stated range.
By their numbers in this assay, from the lowest: compound 3; then compound 1; then compound 2; then compound 4.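

In this assay, among the compounds shown here, the change to 4-chloro-2-fluorophenyl on the amine nitrogen in a ring gives a 23-fold higher number from compound 3 to compound 4 (1.36 log units; beyond the scatter) and is the largest step so far, so this position can move the number much further than the earlier halogen changes showed. The entering group also ends above both other aryl groups, with a 3.0-fold higher number from compound 2 to compound 4 (0.48 log units; beyond the scatter) and an 8.2-fold higher number from compound 1 to compound 4 (0.91 log units; beyond the scatter). Nothing available explains this rise.

Still open, from the compounds shown here alone, is whether the rise follows the chloro or the added fluorine. A phenyl ring carrying chloro alone or fluoro alone on the same nitrogen would separate the two.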